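Ether side-chain variation: from compound 2 to compound 3

A few compounds are considered here, and "the series" means these few. Any claim that something is new, unique, unknown or untested is made for them only; others in the source may bear on it.

Measured so far:
compound 1 `COc1cc(OC)c(-c2coc3cc(OCC=C(C)C)ccc3c2=O)cc1OC` — 680 nM
compound 2 `COc1cc(OC)c(-c2coc3cc(OCc4ccccc4C)ccc3c2=O)cc1OC` — 2900 nM

In a functional assay on HCT-116 cells (Homo sapiens) for antiproliferative activity, read by MTT assay, with a stated time of 24 h (on this read-out lower numbers stand for stronger inhibition and higher numbers for weaker inhibition), compound 2 stands at the higher of the two numbers; compound 1 sits below it, the step being a 4.3-fold higher number from compound 1 to compound 2 (0.63 log units; beyond the scatter). Compound 3 `COc1cc(OC)c(-c2coc3cc(OCc4cccc(C(F)(F)F)c4)ccc3c2=O)cc1OC` differs from compound 2 by 3-(trifluoromethyl)phenyl in place of 2-methylphenyl on a saturated chain carbon bound to an oxygen on an aromatic ring. Going by the values given here, the one measured step, from compound 1 to compound 2, exchanges an alkenyl for an aryl group; no step compares two aryl groups, so it gives no direct guide here. A step within the scatter in either direction is expected, a 1.2-fold lower number from compound 2 to compound 3 (0.06 log units; within the scatter), and compound 3 is estimated at 2500 nM (range 900 nM to 7000 nM).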

Compound 3, half-maximal inhibitory concentration: 3400 nM
Estimate against measurement, compound 3: 1.4-fold (0.13 log units) below; low and high end bracket the measured number.
By their numbers in this assay, from the lowest: compound 1; then compounds 2 and 3 (each within the scatter of the next).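

In this assay, going by these compounds alone, the first step between two aryl groups at this position reads a 1.2-fold higher number from compound 2 to compound 3 (0.07 log units; within the scatter) and does not separate 3-(trifluoromethyl)phenyl from 2-methylphenyl. The exchange of 2-methylprop-1-en-1-yl for 3-(trifluoromethyl)phenyl reads a 5.0-fold higher number from compound 1 to compound 3 (0.70 log units; beyond the scatter) and matches the earlier alkenyl-to-aryl step in direction, with no compound shown going against it. Nothing available explains either step.

The compounds shown leave open whether an unsubstituted phenyl behaves like these two aryl groups. Also open, as far as these compounds go, is how a longer alkyl chain or a chain ending in an amine would compare with 2-methylprop-1-en-1-yl.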